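Replacing 4-hydroxycyclohexyl on an amide-type nitrogen

The source may hold more compounds than are shown below. What is called first, only, known or untested is meant among the compounds shown, and "the series" means these compounds.

In a functional assay on Shh Light II cells (Mus musculus) for inhibition, read by a luciferase reporter (on this read-out higher numbers stand for weaker inhibition and lower numbers for stronger inhibition), compound 3 `O=C(NC1CCC(O)CC1)N1CCC(c2nc(-c3ccc4ccccc4n3)no2)CC1` gives 2700 nM, within the scatter of compound 1 `O=C(NC1CCNCC1)N1CCC(c2nc(-c3ccc4ccccc4n3)no2)CC1` at 2500 nM and of compound 2 `O=C(N1CCC(c2nc(-c3ccc4ccccc4n3)no2)CC1)N1CCCc2ccccc21` at 2300 nM. Compound 4 `O=C(NC1CC[S+]([O-])CC1)N1CCC(c2nc(-c3ccc4ccccc4n3)no2)CC1` differs from compound 3 on an amide-type nitrogen: a group of 7 heavy atoms (5 carbon, 1 oxygen, 1 sulfur; one six-membered non-aromatic ring with 1 hetero atom) in place of a group of 7 heavy atoms (6 carbon, 1 oxygen; one six-membered non-aromatic ring of carbon only), on an amide-type nitrogen. For the measured compounds named here, no measured compound carries this sulfur-containing ring. The nearest evidence is the exchange of groups in this part of the structure, with a 1.1-fold higher number from compound 1 to compound 3 (0.03 log units; within the scatter), a 1.2-fold higher number from compound 2 to compound 3 (0.07 log units; within the scatter) and a 1.1-fold lower number from compound 1 to compound 2 (0.04 log units; within the scatter). All three steps stay within the scatter, so no step beyond the scatter is expected in this assay. The expected change is a 1.1-fold lower number from compound 3 to compound 4 (0.03 log units; within the scatter). Compound 4 is estimated at 2500 nM, with an expected range of 1200 nM to 5000 nM.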

Compound 4, half-maximal inhibitory concentration: 850 nM
The estimate for compound 4 lay 2.9-fold (0.47 log units) above the measured number; measured number below the stated range.
By their numbers in this assay, from the lowest: compound 4; then compounds 2, 1 and 3 (each within the scatter of the next).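

In this assay, the earlier exchanges in this part of the structure all stayed within the scatter, so the position looked indifferent to the group it carried. For the compounds shown here, the sulfur-containing ring is the first group to move the number beyond the scatter, with a 3.2-fold lower number from compound 3 to compound 4 (0.50 log units; beyond the scatter), a 2.7-fold lower number from compound 2 to compound 4 (0.43 log units; beyond the scatter) and a 2.9-fold lower number from compound 1 to compound 4 (0.47 log units; beyond the scatter). Nothing shown here accounts for this shift. On these data alone, what a tetrahydropyran ring or a sulfone in the same place would give stays open, so the result cannot yet be tied to the ring sulfur or to its oxygen.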